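The compounds below may be only part of what the source reports. "The series", "measured", "known", "first", "only" and "open" are said of these compounds alone.

In a functional assay on MCF7 cells (Homo sapiens) for inhibition, read by MTT assay, with a stated time of 3 days (a higher number here means a weaker inhibitor, a lower number a stronger inhibitor), two analogues sharing one core have been measured. Compound 1 `COc1ccc(/C=C\c2cc(OC)c(OC)c(OC)c2)cc1OCc1ccc(Br)cc1` gives 29000 nM, while compound 2 `COCOc1ccccc1/C=C/CCCOc1cc(/C=C\c2cc(OC)c(OC)c(OC)c2)ccc1OC` gives 4400 nM. Compound 2 thus holds the lower of the two numbers, and the gap lies beyond the usual scatter. Going by the values given here, the two differ in more than one place, so no single-change step is available as a guide. Compound 3 `COc1ccc(/C=C\c2cc(OC)c(OC)c(OC)c2)cc1OCCC/C=C/c1ccc(Cl)cc1` has 4-chlorophenyl in place of 2-(methoxymethoxy)phenyl on a double-bonded chain carbon bound to a double-bonded chain carbon. In this assay, a small move towards a higher number is expected, possibly none beyond the scatter, and the span between the two measured values is the only reference. The expected size is a 1.5-fold higher number from compound 2 to compound 3 (0.17 log units; within the scatter). For compound 3 the estimated value is 6500 nM, with an expected range from 1800 nM to 22000 nM.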

Compound 3, half-maximal inhibitory concentration: 40000 nM
Compound 3: middle estimate off by 6.2-fold (0.79 log units), on the low side, outside the stated range (above it).
By their numbers in this assay, from the lowest: compound 2; then compounds 1 and 3 (each within the scatter of the next).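

In this assay, going by these compounds alone, 4-chlorophenyl in place of 2-(methoxymethoxy)phenyl on a double-bonded chain carbon bound to a double-bonded chain carbon gives a 9.1-fold higher number from compound 2 to compound 3 (0.96 log units; beyond the scatter), the first single-change reading here, and it shows that the number responds to the aryl group at this chain end. The exchange of 4-bromophenyl for 4-(4-chlorophenyl)but-3-en-1-yl on a saturated chain carbon bound to an oxygen on an aromatic ring gives a 1.4-fold higher number from compound 1 to compound 3 (0.14 log units; within the scatter), so among these compounds the chain with 4-chlorophenyl does not separate from compound 1, and only compound 2, with 2-(methoxymethoxy)phenyl, stands apart. Nothing available explains the step from compound 2 to compound 3. The compounds shown leave open whether the methoxymethoxy group itself or the substitution pattern of the ring matters. A 2-chlorophenyl, a 4-(methoxymethoxy)phenyl or a 2-hydroxyphenyl on this chain would separate those readings.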